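The compounds below may be only part of what the source reports. "The series", "measured", "known", "first", "only" and "open" are said of these compounds alone.

Measured so far:
compound 1 `COc1cccc(C(=O)Oc2cc3c(cc2C)[C@@H](C(C)C)CC=C3C)c1` — "not active" (no number reported)
compound 2 `CC1=CC[C@H](C(C)C)c2cc(C)c(OC(=O)c3ccc([N+](=O)[O-])cc3)cc21` — 67.8%
compound 3 `CC1=CC[C@H](C(C)C)c2cc(C)c(OC(=O)c3cccc(C(F)(F)F)c3)cc21` — 15%

Among the measured compounds shown here, in a functional assay on HCT-15 cells (Homo sapiens) for antiproliferative activity, read by sulforhodamine B assay, with a stated time of 48 h, tested at 50 uM (on this read-out lower numbers stand for less inhibition and higher numbers for more inhibition at the one concentration tested (going by the name of the read-out)), compound 1 stands without a number: it is reported as "not active" (no number reported), so no value on the percent scale is available for it and no measured step can be drawn from it. Within the same set, compound 2 gives 67.8%, and compound 3 gives 15%; the number for compound 2 is well above that for compound 3, and compound 2 is the one compound here that carries a nitro group on the ester aryl ring.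

Compound 4 `CC1=CC[C@H](C(C)C)c2cc(C)c(OC(=O)c3cccc([N+](=O)[O-])c3)cc21` has not yet been measured. It differs from compound 1 in nitro in place of methoxy on an aromatic carbon. Since compound 1 gives no number, the size of the step into compound 4 in this assay cannot be stated in percent points; the direction is expected upward, from a reading of not active toward a measurable inhibition, though the step may also stay within the scatter and leave compound 4 reported as not active again.

For the measured compounds named here, with compound 2 at 67.8% and compound 3 at 15% as the only numbers available, compound 4 is estimated at 35%, in a range from 10% to 65%, an estimate only.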

Compound 4, a percentage reported as inhibition, at one concentration (the size of the read-out at that concentration, not a potency): 45.9%
The estimate for compound 4 lay 10.9 percentage points below the measured number, within the range that was stated.
By their numbers in this assay, from the lowest: compound 3; then compound 4; then compound 2.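

In this assay, among the compounds shown here, nitro in place of trifluoromethyl on the aromatic carbon gives a number 30.9 percentage points higher from compound 3 to compound 4 (beyond the scatter), so the identity of the group at this one place changes the reading beyond the scatter, a comparison the earlier compounds did not offer. For the compounds shown here, the location of the nitro group also matters, which no earlier pair could show: 3-nitrophenyl in place of 4-nitrophenyl on the carbonyl carbon gives a number 21.9 percentage points lower from compound 2 to compound 4 (beyond the scatter), so the two nitro isomers are separated, with the 4-nitrophenyl ester giving the higher number. The step from compound 1 to compound 4, methoxy to nitro, cannot be read as a size, since compound 1 gives "not active" (no number reported) and offers no number to measure from.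

No measurement at hand accounts for the differences among these groups or between the two nitro isomers. Still open, as far as these compounds go, is how an amine or a carboxylic acid on the same aromatic carbon would read in this assay and whether the order among the nitro and trifluoromethyl compounds would hold in that case.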